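This account rests on a few compounds, and the source may have more. Where it says the series, first, only, none or still open, it means among the compounds named here.

Measured so far:
- compound 1 `C=C(Br)C(=O)Nc1cccc(-c2cn3nc(-c4ccc(OC)c(OC)c4)sc3n2)c1` — 110 nM
- compound 2 `Nc1cccc(-c2cn3c(-c4ccc(Cl)cc4)csc3n2)c1` — 11000 nM
- compound 3 `C=C(Br)C(=O)Nc1cccc(-c2cn3c(-c4ccc(OC)cc4)csc3n2)c1` — 620 nM

In a functional assay on FM3A cells (Mus musculus) for inhibition, read by cell counting, with a stated time of 2 days (a lower number here means a stronger inhibitor, a higher number a weaker inhibitor), compound 1 gives 110 nM, the lowest of the three numbers. Compound 3 stands nearest to it with 620 nM, a gap beyond the scatter, and compound 2 stands furthest with 11000 nM, also well beyond the scatter. No pair among these three differs in one place only, so no single step between measured compounds is available to lean on.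

The unmeasured compound 4 `C=C(Br)C(=O)Nc1cccc(-c2cn3nc(Cc4ccc(Cl)cc4)sc3n2)c1` is reached from compound 1 by one change: 4-chlorobenzyl in place of 3,4-dimethoxyphenyl on an aromatic carbon. Nothing measured here isolates the effect of this exchange. Within the data shown here, since compound 3, which carries only one methoxy group on a related core, gives 620 nM, a weakening step is expected in this assay for this change, but of moderate size. The step from compound 1 to compound 4 is estimated at a 3.6-fold higher number from compound 1 to compound 4 (0.56 log units; beyond the scatter). Compound 4 is expected to give about 400 nM in this assay, within a range from 100 nM to 1600 nM.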

Compound 4, half-maximal inhibitory concentration: 1100 nM
Compound 4: the middle estimate sits 2.8-fold (0.44 log units) below what was measured; the range from low to high includes it.
By their numbers in this assay, from the lowest: compound 1; then compounds 3 and 4 (each within the scatter of the next); then compound 2.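

In this assay, 4-chlorobenzyl in place of 3,4-dimethoxyphenyl on this aromatic carbon, next to the ring nitrogen and the ring sulfur, gives a 10-fold higher number from compound 1 to compound 4 (1.00 log units; beyond the scatter), a step beyond the scatter and the first that isolates a single place in this set. It shows that the number at this position responds to the group it carries, and that this exchange, in which a group with 2 hydrogen-bond acceptors gives way to one with 0, costs strength on the core of compound 1. No measurement shown here accounts for the loss.

Among these compounds, the single step cannot separate the methoxy groups, the chlorine and the benzyl form from one another. On these data alone, how an unsubstituted benzyl, a 3,4-dimethoxybenzyl or an amine would fare at this position remains open.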